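The source may report more compounds than this note shows. Statements on the series, on what has been measured and on what is new or still open speak of the compounds shown alone.

Working notes on cytotoxicity in a toxicity assay on NIH3T3 cells (Mus musculus) for cytotoxicity, read by resazurin assay (a higher number here means that more compound is needed for the effect, a lower number that less compound is needed), for the shared core of compound 1 `c1ccc(-c2ccc(Cn3cncc3CNc3cccc(-c4ccccc4)c3)cc2)cc1`, which gives 10000 nM in this assay. For compound 2 `c1ccc(-c2ccc(Cn3cncc3CNc3ccc(-c4ccc[nH]4)c(-c4ccccc4)c3)cc2)cc1` this assay reports only a limit, > 10000 nM. For compound 3 `COC(=O)c1ccc(NCc2cncn2Cc2ccc(-c3ccccc3)cc2)cc1-c1ccccc1` this assay likewise reports only a limit, > 1000 nM. Compound 3 thus stands on the numbers shown as a limit alone, and one further value of the three is also a limit, so no number places compound 3 above or below its neighbours. The measured steps read as follows: a number no lower from compound 1 to compound 2 (the limit leaves the size open); a step that the limit leaves unreadable from compound 1 to compound 3; a step that the two limits leave unreadable from compound 2 to compound 3. The limit that holds compound 3 is the limit of > 1000 nM in this assay, at which 1 of the 3 values shown sits. The limit that holds compound 2 is the limit of > 10000 nM in this assay, at which 1 of the 3 values shown sits. Compound 4 `c1ccc(-c2ccc(Cn3cncc3CNc3ccc(N4CCCCC4)c(-c4ccccc4)c3)cc2)cc1` differs from compound 3 by piperidin-1-yl in place of methoxycarbonyl on an aromatic carbon. Going by the values given here, the steps that touch this same aromatic carbon, from compound 1 to compound 3 and from compound 2 to compound 3, carry no readable size, so no measured step sets a direction or size for the change to piperidin-1-yl; all three measured compounds sit at or near the top of the measured range, and no step beyond the scatter is expected. Compound 4 is accordingly estimated at 10000 nM in this assay, with an expected range from 3000 nM to 30000 nM. The expected step that the limit leaves unreadable from compound 3 to compound 4 is read as no change beyond the scatter, with a fair chance that only a limit is reported.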

Compound 4, half-maximal effective concentration: > 1000 nM
Compound 4: a limit, no number; the forecaster's own chance of this, stated with the estimate: 60%; the middle value lies beyond the limit too.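

In this assay compound 4 gives > 1000 nM, which is a limit and not a number. No new step can be read between compound 4 and compound 1, compound 2 or compound 3. The compounds shown leave open whether piperidin-1-yl, methoxycarbonyl or 1H-pyrrol-2-yl on this aromatic carbon changes the value relative to hydrogen.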